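Cyano on the pyrazole across two different cores

The source may hold more compounds than are shown below. What is called first, only, known or untested is meant among the compounds shown, and "the series" means these compounds.

Compound 1 `CN(CCN(C)C(=O)n1cccn1)Cc1ccc(OCc2ccccc2)cc1` and compound 2 `CN(CCN(C)C(=O)n1cc(C#N)cn1)Cc1ccc(OCc2ccccc2)cc1` share one core, while compound 3 `O=C(NCc1ccc(OC(c2ccccc2)c2ccccc2)cc1)n1cccn1` and compound 4 `N#Cc1cnn(C(=O)NCc2ccc(OC(c3ccccc3)c3ccccc3)cc2)c1` share another; the difference between the two cores is not broken down here. In an assay on membranes from brain for binding affinity to Monoglyceride lipase (Mus musculus), read by fluorescence, with stated times of 1 h and 30 min (on this read-out lower numbers stand for stronger inhibition and higher numbers for weaker inhibition), compound 1 gives 660 nM and compound 2 gives 260 nM, so the step of a 2.5-fold lower number from compound 1 to compound 2 (0.40 log units; beyond the scatter) follows from the change (cyano in place of hydrogen on an aromatic carbon). For compound 3 this assay reports only a limit, > 100000 nM, which is the limit of > 100000 nM in this assay, at which 1 of the 3 values shown sits. Compound 4 carries the same change, (cyano in place of hydrogen on an aromatic carbon). Since compound 3 sits at a limit, the step from compound 3 to compound 4 is expected to be an at least 1.6-fold lower number from compound 3 to compound 4 (0.22 log units; that floor lies within the scatter), resting on the modest size of the step from compound 1 to compound 2. Compound 4 is therefore estimated at 60000 nM in this assay, between 15000 nM and 300000 nM, with a real chance that only a limit is reported again.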

Compound 4, half-maximal inhibitory concentration: > 100000 nM
Compound 4 was reported as a limit; the forecaster's own chance of this, stated with the estimate: 65%; middle value at least 1.6-fold (0.22 log units) away from the limit.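

In this assay, going by these compounds alone, compound 4 is reported only as a limit, > 100000 nM, as compound 3 is, so no step between compound 3 and compound 4 can be read. The compounds shown leave open whether cyano changes the read-out on this core at all.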